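The source may hold more compounds than are shown below. What is called first, only, known or untested is meant among the compounds shown, and "the series" means these compounds.

Working notes on the series. Compound 1 `CC(C)(C)c1ccc(CNCCCNS(=O)(=O)c2cc(C(F)(F)F)cc(C(F)(F)F)c2)cc1` is the reference point. In a toxicity assay on MCF-10A cells (Homo sapiens) for inhibition, read by MTT assay, with a stated time of 72 h (a lower number here means a stronger inhibitor of growth, a higher number a weaker inhibitor of growth), compound 1 gives 3200 nM. Compound 3 `O=S(=O)(NCCCNCc1ccc(-c2ccccc2)cc1)c1cc(C(F)(F)F)cc(C(F)(F)F)c1` gives 2800 nM, and compound 2 `O=S(=O)(NCCNCc1cccc2ccccc12)c1cc(C(F)(F)F)cc(C(F)(F)F)c1` gives 22000 nM. Among these three numbers compound 1 stands second highest: its nearest neighbour is compound 3, and the only measured single change, phenyl in place of tert-butyl on an aromatic carbon, reads a 1.1-fold lower number from compound 1 to compound 3 (0.06 log units; within the scatter), within the scatter. Compound 2 differs from compound 1 in more than one place, so the two can only be set side by side; compound 2 shows the highest number of the three, beyond the scatter from compound 1.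

The next compound is compound 4 `COc1ccccc1CNCCCNS(=O)(=O)c1cc(C(F)(F)F)cc(C(F)(F)F)c1`. It differs from compound 1 as follows: 2-methoxyphenyl in place of 4-(tert-butyl)phenyl on a saturated chain carbon bound to an amine nitrogen. Among the measured compounds shown here, no measured step covers this exchange; the one step in hand, from compound 1 to compound 3, bears on it only in that it touches the same group and was flat. For the measured compounds named here, the entering group has no measured counterpart, so the expectation is uncertain, leaning toward a moderately higher number. For compound 4 the step is expected to be a 1.9-fold higher number from compound 1 to compound 4 (0.27 log units; within the scatter). Compound 4 is therefore estimated at 6000 nM in this assay, within a range from 2500 nM to 15000 nM.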

Compound 4, concentration for 50% growth inhibition: 5500 nM
For compound 4 the middle estimate is 1.1-fold (0.04 log units) above the measured one; the range from low to high includes it.
By their numbers in this assay, from the lowest: compounds 3, 1 and 4 (each within the scatter of the next); then compound 2.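

With this assay as the read-out, the exchange at the saturated chain carbon bound to an amine nitrogen gives a 1.7-fold higher number from compound 1 to compound 4 (0.24 log units; within the scatter), so a second replacement of the 4-(tert-butyl)phenyl group is also flat. The earlier step replaced only the tert-butyl group, whereas this one goes from 4-(tert-butyl)benzyl to 2-methoxybenzyl: the 10 heavy atoms, all carbon, of the leaving group give way to 8 heavy atoms including one oxygen, with one hydrogen-bond acceptor where there were none, and the number still does not move beyond the scatter. Nothing available bears on why this step stays flat.

Among the compounds shown here, the substituent and its place on the aromatic ring change together here, so the single step cannot separate the methoxy group from the loss of the tert-butyl group, and a 2-(tert-butyl)phenyl or an unsubstituted phenyl group would be needed to part the two. As far as these compounds go, it also remains open whether a substituent such as an amine or a carboxylic acid on that ring, or a longer chain in the linker, would move the number beyond the scatter.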